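Solubility in a quinoline series: tert-butylphenyl follows naphthyl

The source may report more compounds than this note shows. Statements on the series, on what has been measured and on what is new or still open speak of the compounds shown alone.

Measured compounds:
Compound 1, `COc1cccc(CNCCCNc2ccnc3cc(-c4ccc(C(F)(F)F)cc4)ccc23)c1O`, 32000 nM
Compound 2, `COc1cccc(Oc2ccc3c(NCCCNCc4cccc(OC)c4O)ccnc3c2)c1`, 14500 nM
Compound 3, `COc1cccc(CNCCCNc2ccnc3cc(-c4cccc5ccccc45)ccc23)c1O`, 32000 nM

In a physicochemical assay for solubility, with a stated time of 18 h, at pH 7.4 (on this read-out lower numbers stand for lower solubility and higher numbers for higher solubility), compound 3 gives 32000 nM, level with compound 1 and together with it the highest of the three numbers; against compound 2 it shows a 2.2-fold higher number from compound 2 to compound 3 (0.34 log units; beyond the scatter). The unmeasured compound 4, `COc1cccc(CNCCCNc2ccnc3cc(-c4ccc(C(C)(C)C)cc4)ccc23)c1O`, differs from compound 3 by 4-(tert-butyl)phenyl in place of naphthalen-1-yl on an aromatic carbon. The step that bears most directly on this change is no change at the digits printed from compound 1 to compound 3 (within the scatter), which swapped one aryl group for another at the same position without moving this assay beyond the scatter; only the aryl ether change in a 2.2-fold lower number from compound 1 to compound 2 (0.34 log units; beyond the scatter) shifted it. For compound 4, a step of about a 1.1-fold lower number from compound 3 to compound 4 (0.06 log units; within the scatter) is therefore expected, within the scatter. Compound 4 is estimated at 28000 nM, ranging from 11000 nM to 50000 nM.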

Compound 4, solubility: 32000 nM
Compound 4: middle estimate off by 1.1-fold (0.06 log units), on the low side; the measured number falls inside the stated range.
By their numbers in this assay, from the lowest: compound 2; then compounds 1, 3 and 4 (each within the scatter of the next).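

In this assay, 4-(tert-butyl)phenyl in place of naphthalen-1-yl gives no change at the digits printed from compound 3 to compound 4 (within the scatter) even though one aromatic ring replaces two at this position, so this change in ring count leaves the number within the scatter. Tert-butyl in place of trifluoromethyl likewise gives no change at the digits printed from compound 1 to compound 4 (within the scatter) and so adds a third aryl group at the same level. Compound 2 remains the only one apart, with a 2.2-fold higher number from compound 2 to compound 4 (0.34 log units; beyond the scatter) showing the same gap for the new compound.

On these data alone, whether an amine or a carboxylic acid on this aryl ring would move the number remains open. The compounds also come with no evidence that explains these numbers.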